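The source may report more compounds than this note shows. Statements on the series, on what has been measured and on what is new or still open speak of the compounds shown alone.

Three compounds have been measured in a functional assay, read by spectrophotometry, with a stated time of 3 min; on this read-out lower numbers stand for stronger inhibition and higher numbers for weaker inhibition:

compound 1 `Cc1ccc2[nH]c(=O)c(/C=N/c3ccccc3O)cc2c1`: 8240 nM
compound 2 `CCCC/N=C/c1cc2cc(C)ccc2[nH]c1=O`: 43300 nM
compound 3 `CCCC/N=C/c1cc2ccccc2[nH]c1=O`: 1810000 nM

Compound 1 gives the lowest of the three numbers, and both of its steps to the other compounds lie beyond the scatter. The cores of compound 1 and compound 2 differ in 2-hydroxyphenyl in place of butyl on a double-bonded nitrogen; the step of a 5.3-fold higher number from compound 1 to compound 2 (0.72 log units; beyond the scatter) is modest. Compound 2 and compound 3 differ in hydrogen in place of methyl on an aromatic carbon, and this change brought a 42-fold higher number from compound 2 to compound 3 (1.62 log units; beyond the scatter), a large step toward weaker inhibition.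

Compound 4 `O=c1[nH]c2ccccc2cc1/C=N/c1ccccc1O` has not yet been measured. It differs from compound 1 in hydrogen in place of methyl on an aromatic carbon. The place of this change is described in the same words as for the pair of compound 2 and compound 3, so it is the same change, occurring twice among the compounds shown. Within the data shown here, the only measured instance of it, from compound 2 to compound 3, was large and beyond the scatter, and that is the sole basis for what follows; whether the change carries over to the core of compound 1 cannot be checked from these data. The step expected for compound 4 is a 24-fold higher number from compound 1 to compound 4 (1.39 log units; beyond the scatter). This rests on compound 2 and compound 3, where the same change gave a 42-fold higher number from compound 2 to compound 3 (1.62 log units; beyond the scatter). For compound 4 the estimate in this assay is 200000 nM, expected to fall between 40000 nM and 1000000 nM.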

Compound 4, half-maximal inhibitory concentration: 11700 nM
Compound 4: the middle estimate sits 17-fold (1.23 log units) above what was measured; the measured number lies below the stated range.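

In this assay, hydrogen in place of methyl on an aromatic carbon gave a 1.4-fold higher number from compound 1 to compound 4 (0.15 log units; within the scatter), so on the core of compound 1, which carries 2-hydroxyphenyl on the double-bonded nitrogen, compound 1 and compound 4 cannot be told apart. The same change therefore did not carry the same size of step from the butyl core of compound 2 to the core of compound 1, and the two instances differ by more than the scatter allows: the same change on two cores in this assay, a 42-fold higher number (1.62 log units; beyond the scatter) from compound 2 to compound 3 and a 1.4-fold higher number (0.15 log units; within the scatter) from compound 1 to compound 4, 29-fold (1.47 log units) apart, beyond the scatter of two such steps This shows that, within this series, the step seen on one core cannot be transferred to the other, but with only these two instances it does not show a rule for other cores or explain why the two steps differ.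

The compounds shown leave open whether the large step belongs to butyl in particular or would also appear with a longer chain or an unsubstituted phenyl on the double-bonded nitrogen. They also leave open how a chlorine or a methoxy group in place of the methyl on that aromatic carbon would behave on either core.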